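A few compounds are considered here, and "the series" means these few. Any claim that something is new, unique, unknown or untested is made for them only; others in the source may bear on it.

Measured so far in an ADME assay on MT4 cells (Homo sapiens) for cytotoxicity, read by MTT assay; on this read-out higher numbers stand for lower toxicity in this test and lower numbers for higher toxicity in this test:
- compound 1 `O=C1c2ccccc2C(=O)N1CCOC(=S)N(C(=O)c1cccc(F)c1F)c1ccc(Cl)cc1`: 58000 nM
- compound 2 `O=C1c2ccccc2C(=O)N1CCOC(=S)N(C(=O)c1ccc(F)cc1F)c1ccc(Cl)cc1`: 52000 nM
- compound 3 `Cc1cc(C(=O)N(C(=S)OCCN2C(=O)c3ccccc3C2=O)c2ccc(Cl)cc2)c(C)o1`: 40000 nM

Compound 3 stands level with the other two, as all three values lie within the usual scatter of repeat measurements. The data show a 1.5-fold lower number from compound 1 to compound 3 (0.16 log units; within the scatter) and a 1.3-fold lower number from compound 2 to compound 3 (0.11 log units; within the scatter), and the remaining pair shows a 1.1-fold lower number from compound 1 to compound 2 (0.05 log units; within the scatter) as well.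

The next compound is compound 4 `O=C1c2ccccc2C(=O)N1CCOC(=S)N(C(=O)c1cc2ccccc2s1)c1ccc(Cl)cc1`, which has 1-benzothiophen-2-yl in place of 2,5-dimethylfuran-3-yl on a carbonyl carbon.

All three measured steps swap the group at this same carbonyl carbon, and none of them goes beyond the scatter. Going by the values given here, a clear shift is therefore not expected here, although no measured compound carries 1-benzothiophen-2-yl, so the range is kept wide. The expected outcome is a 1.1-fold higher number from compound 3 to compound 4 (0.02 log units; within the scatter), a step no larger than the scatter.

Compound 4 is estimated at 42000 nM (expected range 16000 nM to 100000 nM).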

Compound 4, half-maximal cytotoxic concentration: 56000 nM
For compound 4 the middle estimate is 1.3-fold (0.12 log units) below the measured one, and the stated range covers the measured number.
By their numbers in this assay, from the lowest: compounds 3, 2, 4 and 1 (each within the scatter of the next).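

Placing 1-benzothiophen-2-yl on the carbonyl carbon brings sulfur and a second aromatic ring to this position for the first time, yet it leaves the result in this assay unmoved: the three comparisons read (a 1.4-fold higher number from compound 3 to compound 4 (0.15 log units; within the scatter)), (a 1.1-fold higher number from compound 2 to compound 4 (0.03 log units; within the scatter)) and (a 1.0-fold lower number from compound 1 to compound 4 (0.02 log units; within the scatter)). Among these four compounds, then, even a group with more heavy atoms than 2,5-dimethylfuran-3-yl gives no change beyond the scatter, which widens the range of aromatic groups seen to behave alike here. Nothing available explains why these numbers stay level.

All four groups at this position are uncharged aromatic rings. As far as these compounds go, whether an amine, a carboxylic acid or a simple alkyl chain on this carbonyl carbon would shift the number remains open, as does any change elsewhere in the shared core.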